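Replacing the Acid with a Methyl Ester

The source may hold more compounds than are shown below. What is called first, only, known or untested is meant among the compounds shown, and "the series" means these compounds.

Compound 1 `Cc1c(OCCCCOc2cccc(C(=O)O)c2)ccc(C(=O)CC(C)C)c1C` gives 12.1% in an assay on HEK293 cells for positive allosteric modulation of metabotropic glutamate receptor 2 (Rattus norvegicus), read by thallium flux, with a stated time of 2.5 min; a lower number here means a smaller maximal response, a higher number a larger maximal response.
Compound 2 `Cc1c(OCCCCOc2cccc(C(=O)O)c2)ccc(C(=O)CC2CCCC2)c1C` gives 22.4%.

Within the data shown here, compound 1 stands lowest of the two measured numbers; the only measured step is a number 10.3 percentage points higher from compound 1 to compound 2 (beyond the scatter). Compound 3 `COC(=O)c1ccc(OCCCCOc2ccc(C(=O)CC(C)C)c(C)c2C)cc1` differs from compound 1 in that (4-(methoxycarbonyl)phenyl in place of 3-carboxyphenyl on an oxygen on a saturated carbon). The measured step concerns the cyclopentyl for isopropyl exchange, a different part of the molecule, so it gives no guide to this change. With nothing to build on, no step beyond the scatter is expected, an estimated a number 2.9 percentage points higher from compound 1 to compound 3 (within the scatter). Compound 3 is therefore expected to reach 15%, with a likely range from 0% to 40%.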

Compound 3, largest response reached (reported as percent of maximum), in percent of the reference or control that the assay uses: 15.9%
Compound 3: middle estimate off by 0.9 percentage points, on the low side; measured number inside the range.
By their numbers in this assay, from the lowest: compounds 1, 3 and 2 (each within the scatter of the next, the first and the last beyond it).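

In this assay, putting 4-(methoxycarbonyl)phenyl in place of 3-carboxyphenyl on this oxygen gives a number 3.8 percentage points higher from compound 1 to compound 3 (within the scatter), so this position tolerates the loss of the acid and its hydrogen-bond donor without a step beyond the scatter. The swap alters both the group and its place on the ring, and this single step cannot separate the two. No evidence shown explains the result.

A 3-(methoxycarbonyl)phenyl or 4-carboxyphenyl group on the same oxygen would separate those two changes. As far as these compounds go, whether a primary amide would behave the same way here remains open.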